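Methyl on the ring-bound phenyl of a thiazolidinone amide

This account rests on a few compounds, and the source may have more. Where it says the series, first, only, none or still open, it means among the compounds named here.

Measured compounds:
compound 1 `COc1ccc(F)cc1N1C(=O)CSC1c1cccc(C(=O)NCCCCc2ccccc2)c1`, 95%
compound 2 `O=C(NCCCCc1ccccc1)c1cccc(C2SCC(=O)N2c2ccccc2)c1`, 96%

Compound 2 gives the higher of the two numbers in a functional assay on HOS-TE85 cells (Homo sapiens) for inhibition, read by CCK-8 assay, with a stated time of 72 h, tested at 1 uM (a higher number here means more inhibition at the concentration tested (going by the name of the read-out), a lower number less inhibition), though its step from compound 1 is a number 1 percentage points higher from compound 1 to compound 2 (within the scatter). That step, replacing the substituted aryl group on the ring nitrogen with a plain phenyl, is the only measured one that bears on the next change.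

Compound 3 `Cc1cccc(N2C(=O)CSC2c2cccc(C(=O)NCCCCc3ccccc3)c2)c1` differs from compound 2 by methyl in place of hydrogen on an aromatic carbon, on the same aryl group that was varied before. Because that earlier step was a number 1 percentage points higher from compound 1 to compound 2 (within the scatter), a second change on this ring is expected to move the read-out no further than the scatter. The step from compound 2 to compound 3 in this assay is therefore estimated at a number 2 percentage points lower from compound 2 to compound 3 (within the scatter). Compound 3 is expected to give 94% in this assay, within a range of 84% to 99%.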

Compound 3, a percentage reported as inhibition, at one concentration (the size of the read-out at that concentration, not a potency): 96%
Estimate against measurement, compound 3: 2 percentage points below; the range from low to high includes it.
By their numbers in this assay, from the lowest: compounds 1, 2 and 3 (each within the scatter of the next).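

In this assay, methyl in place of hydrogen on an aromatic carbon, meta to a large group, gives no change at the digits printed from compound 2 to compound 3 (within the scatter), so the number stays level with the added carbon at this position on the phenyl. Set against the original aryl group, 3-methylphenyl in place of 5-fluoro-2-methoxyphenyl gives a number 1 percentage points higher from compound 1 to compound 3 (within the scatter), which means that three different aryl groups on the ring nitrogen now read alike within the scatter, where the earlier comparison rested on a single pair. Nothing measured here offers an explanation for this sameness.

As far as these compounds go, it remains open whether an amine or a carboxylic acid at this place, or a longer chain such as propyl in place of the methyl, would move the read-out beyond the scatter. Also open, from the compounds shown here alone, is whether these three compounds would separate at a lower tested concentration.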